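This account rests on a few compounds, and the source may have more. Where it says the series, first, only, none or still open, it means among the compounds named here.

Working notes on the series. Compound 1 `c1cn2cc(-c3ccsc3)nc(-c3ccc4ncn(C5CCCCC5)c4c3)c2n1` and compound 2 `Clc1ccc(-c2cn3ccnc3c(-c3ccc4ncn(C5CCCCC5)c4c3)n2)cc1` share one core and differ only in the aryl group on the aromatic carbon. For the measured compounds named here, in a physicochemical assay for lipophilicity, using the shake flask method, in phosphate buffer, measured as octanol-water partition, with a stated time of 85 min, at pH 7.4 (on this read-out higher numbers stand for higher lipophilicity and lower numbers for lower lipophilicity), compound 1 gives 1.81, and compound 2 gives 1.51; the step of a number 0.30 log units lower from compound 1 to compound 2 (within the scatter) is the only measured step so far, and it lies within the scatter, so the two numbers stand together rather than in any order.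

Compound 3 `FC(F)(F)c1cccc(-c2cn3ccnc3c(-c3ccc4ncn(C5CCCCC5)c4c3)n2)c1` is the next member. Relative to compound 2 the change is 3-(trifluoromethyl)phenyl in place of 4-chlorophenyl on an aromatic carbon. Going by the values given here, no measured step covers a 3-(trifluoromethyl)phenyl group; the step from compound 1 to compound 2 is the only one at this position and it was within the scatter. On that basis the expected step of a number 0.19 log units higher from compound 2 to compound 3 (within the scatter) is estimated to be small, with a slight upward lean at most and no clear move beyond the scatter. Compound 3 is therefore estimated to give 1.7 in this assay, within a range of 1.3 to 2.1.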

Compound 3, partition coefficient: 1.72
Estimate against measurement, compound 3: 0.02 log units below; measured number inside the range.
By their numbers in this assay, from the lowest: compounds 2, 3 and 1 (each within the scatter of the next).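

In this assay the exchange of 4-chlorophenyl for 3-(trifluoromethyl)phenyl is a number 0.21 log units higher from compound 2 to compound 3 (within the scatter) and the exchange of thiophen-3-yl for the same group is a number 0.09 log units lower from compound 1 to compound 3 (within the scatter) and with these two steps all three pairs at this position now lie within the scatter. The position has therefore taken a thiophene ring and two differently substituted phenyl rings without any pair separating, so the three compounds stand as one group on this read-out. Even the larger entering group, with 10 heavy atoms against 7 for 4-chlorophenyl, gives no step beyond the scatter, and nothing at hand bears on why these numbers stand together.

The 4-chlorophenyl and 3-(trifluoromethyl)phenyl groups differ both in their substituent and in where it sits on the phenyl ring, so a pair such as 4-chlorophenyl and 4-(trifluoromethyl)phenyl would be needed to take those two changes apart. Going by these compounds, it also remains open whether a non-aromatic group at this position, such as an amine or a carboxylic acid, would give a step beyond the scatter.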